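This account rests on a few compounds, and the source may have more. Where it says the series, first, only, none or still open, it means among the compounds named here.

Three related compounds share one core and differ in the groups attached to it. In a functional assay on C6 cells (Rattus norvegicus) for cytotoxicity, read by MTT assay, with a stated time of 24 h, tested at 50 ug/mL (on this read-out higher numbers stand for a weaker effect at the one concentration tested and lower numbers for a stronger effect), compound 1 `Cc1ccc(-c2cs/c(=N/NC(=O)CSc3nnnn3-c3ccccc3)n2-c2ccccc2)cc1` gives 29.5%. Compound 3 `COc1ccc(-c2cs/c(=N/NC(=O)CSc3nnc(C)s3)n2-c2ccccc2)cc1` gives 31.5% in this assay, and compound 2 `O=C(CSc1ncccn1)N/N=c1/scc(-c2ccc(F)cc2)n1-c1ccccc1` gives 55.5%. Compound 1 thus shows the lowest of the three numbers, but its gap to compound 3 lies within the usual scatter of repeated measurements, so these two cannot be told apart on this read-out; only compound 2 stands clearly apart, with a weaker effect. Compound 2 differs from compound 1 in more than one place, so its higher number cannot be pinned to any single group.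

Compound 4 `O=C(CSc1nnnn1-c1ccccc1)N/N=c1/scc(-c2ccc(Cl)cc2)n1-c1ccccc1` has not yet been measured. It differs from compound 1 in one place: chloro in place of methyl on an aromatic carbon. Going by the values given here, no pair among the measured compounds shows this change by itself, so there is no measured step to lean on. The expectation is a modest rise, with the step of a number 8.5 percentage points higher from compound 1 to compound 4 (within the scatter) estimated to stay close to the scatter. For compound 4 the estimated value in this assay is 38%, with an expected range from 22% to 58%.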

Compound 4, a percentage reported as activity, at one concentration (the size of the read-out at that concentration, not a potency): 60%
Beside the measured number, compound 4's estimate is 22 percentage points below it, and the stated range ends below it.
By their numbers in this assay, from the lowest: compounds 1 and 3 (each within the scatter of the next); then compounds 2 and 4 (each within the scatter of the next).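

Going by these compounds alone, exchanging methyl for chloro on this aromatic carbon, para to a large group, is the first change made by itself that can be read in this assay, and it gives a number 30.5 percentage points higher from compound 1 to compound 4 (beyond the scatter), a large step towards a weaker effect at the one concentration tested. Within the data shown here, this position therefore matters on this read-out: with the rest of the molecule unchanged, going from 4-methylphenyl to 4-chlorophenyl moves the number well beyond the usual scatter, something the earlier compounds could not show because they all differ from one another in more than one place. Nothing measured here bears on why this single exchange produces a step of this size.

On these data alone, with only methyl and chloro compared directly, it remains open how an amine, a hydroxyl group or a longer chain such as propyl would read at this position on the core of compound 1. As far as these compounds go, the fluoro group of compound 2 and the methoxy group of compound 3 come with other differences, so they do not settle this, and whether the same exchange would give a similar step with a different group on the other side of the molecule also stays open.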